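The source may hold more compounds than are shown below. What is called first, only, known or untested is meant among the compounds shown, and "the series" means these compounds.

Compound 1 `CC(C)(C)C(=O)N1CCC[C@H]1C(=O)N1CCC(NS(=O)(=O)c2cc(S(=O)(=O)c3ccccc3)ccc2C(F)(F)F)CC1` and compound 2 `CN1CCC[C@H]1C(=O)N1CCC(NS(=O)(=O)c2cc(S(=O)(=O)c3ccccc3)ccc2C(F)(F)F)CC1` share one core and differ only at the ring amine nitrogen. In an assay on isolated protein for binding affinity to secreted frizzled-related protein 1 (Homo sapiens), read by fluorescence (on this read-out lower numbers stand for stronger inhibition and higher numbers for weaker inhibition), compound 1 gives 40 nM, and in this assay compound 2 gives 120 nM. The step of a 3.0-fold higher number from compound 1 to compound 2 (0.48 log units; beyond the scatter) is the only measured one, and it leaves compound 2 with the higher of the two numbers shown.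

Compound 3 `O=C([C@@H]1CCCN1Cc1ccccc1)N1CCC(NS(=O)(=O)c2cc(S(=O)(=O)c3ccccc3)ccc2C(F)(F)F)CC1` is reached from compound 2 by phenyl in place of hydrogen on a saturated chain carbon bound to an amine nitrogen in a ring; cut one bond further out, the change reads methyl to benzyl, or 1-methylpyrrolidin-2-yl to 1-benzylpyrrolidin-2-yl. Within the data shown here, no measured step covers this exact change. Among the measured compounds shown here, the one step that bears on it, a 3.0-fold higher number from compound 1 to compound 2 (0.48 log units; beyond the scatter), shows that the smaller substituent on that nitrogen went with the higher number, so adding the phenyl to the methyl points back toward a lower number, though a benzyl is not a (tert-butyl)carbonyl and the direction is uncertain. On this basis the step from compound 2 to compound 3 is expected to be a 1.7-fold lower number from compound 2 to compound 3 (0.23 log units; within the scatter), modest at most. Compound 3 is therefore estimated at 70 nM, with a range from 25 nM to 200 nM.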

Compound 3, half-maximal inhibitory concentration in the secreted frizzled-related protein 1 assay: 1400 nM
For compound 3 the middle estimate is 20-fold (1.30 log units) below the measured one; the measured number lies above the stated range.
By their numbers in the secreted frizzled-related protein 1 assay, from the lowest: compound 1; then compound 2; then compound 3.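

On the amine nitrogen in a ring, putting phenyl in place of hydrogen on the saturated chain carbon does not lead back toward compound 1 in the secreted frizzled-related protein 1 assay: the change gives a 12-fold higher number from compound 2 to compound 3 (1.07 log units; beyond the scatter) and, measured against the (tert-butyl)carbonyl, benzyl gives a 35-fold higher number from compound 1 to compound 3 (1.54 log units; beyond the scatter) on this read-out. The methyl of compound 2 therefore falls between the other two groups, and the earlier link between a smaller group on this nitrogen and a higher number does not hold as a trend, with compound 3 going against it. The same change also comes with lower solubility in a physicochemical assay for solubility; a higher number here means a more soluble compound, a lower number a less soluble compound: the measured solubility of compound 2, 100000 nM, and of compound 3, 25000 nM, a 4.0-fold lower number (0.60 log units; beyond the scatter). In the physicochemical assay compound 2 gives 100000 nM and compound 3 gives 25000 nM.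

With three groups on this nitrogen, the compounds shown leave open whether the higher number in the secreted frizzled-related protein 1 assay follows from the phenyl ring itself or from the absence of a carbonyl on that nitrogen. An acetyl group on the nitrogen would test the carbonyl apart from the tert-butyl, while a cyclohexylmethyl group would test the benzyl shape without its aromatic ring.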